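This account rests on a few compounds, and the source may have more. Where it says the series, first, only, none or still open, it means among the compounds named here.

Working notes on the series. Of the compounds shown here, three share one core and have been measured in an assay on CHO cells for displacement of a labelled ligand from adenosine receptor A3 (Homo sapiens), read by scintillation counting; a higher number here means a weaker inhibitor, a lower number a stronger inhibitor. Compound 1, `C#CCCCC#Cc1nc(NCc2cccc(Cl)c2)c2ncn([C@@H]3[C@H](O)[C@H](O)[C@]4(C(=O)NC)C[C@H]34)c2n1`, gives 23.6 nM. Compound 2, `CNC(=O)[C@@]12C[C@@H]1[C@@H](n1cnc3c(NCc4cccc(Cl)c4)nc(C#CCCCCc4cn(Cc5ccc(-n6sccc6=O)cc5)nn4)nc31)[C@H](O)[C@@H]2O`, gives 102 nM. Compound 3, `CNC(=O)[C@@]12C[C@@H]1[C@@H](n1cnc3c(NCc4cccc(Cl)c4)nc(C#CCCCCc4cn(-c5ccc(C(=O)O)cc5)nn4)nc31)[C@H](O)[C@@H]2O`, gives 180 nM, the highest of the three numbers; the gap to compound 2 is within the scatter, the gap to compound 1 is beyond it, so compound 3 can only be said to be weaker than compound 1.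

The next step keeps the chain from compound 3 and replaces the group on the aromatic nitrogen of the triazole: 3-nitrophenyl in place of 4-carboxyphenyl on an aromatic nitrogen. This gives compound 4, `CNC(=O)[C@@]12C[C@@H]1[C@@H](n1cnc3c(NCc4cccc(Cl)c4)nc(C#CCCCCc4cn(-c5cccc([N+](=O)[O-])c5)nn4)nc31)[C@H](O)[C@@H]2O`. Within the data shown here, no step between measured compounds is recorded for such an exchange. Compound 2 and compound 3 carry different groups on the same ring nitrogen and their values lie within the scatter of each other, so the exchange at this position is expected to move this assay little, with no direction beyond the scatter; the step of a 1.2-fold lower number from compound 3 to compound 4 (0.08 log units; within the scatter) is what is estimated. Compound 4 is therefore expected to give about 150 nM in this assay, in a range from 60 nM to 400 nM.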

Compound 4, inhibition constant: 10.6 nM
Beside the measured number, compound 4's estimate is 14-fold (1.15 log units) above it; the measured number lies below the stated range.
By their numbers in this assay, from the lowest: compound 4; then compound 1; then compounds 2 and 3 (each within the scatter of the next).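

The group on the aromatic nitrogen of the five-membered aromatic ring is not a neutral position in this assay: 3-nitrophenyl in place of 4-carboxyphenyl gives a 17-fold lower number from compound 3 to compound 4 (1.23 log units; beyond the scatter). This large step comes with no change in the heavy-atom count or in the six-membered aromatic ring of carbon only, while the counts of hydrogen-bond donors and acceptors do differ. No measurement shown accounts for the step.

The nitro group and the point of attachment on the phenyl ring change together in this one step, and the compounds shown do not separate the two. From the compounds shown here alone, how an unsubstituted phenyl group, or a phenyl ring bearing an amine or a nitrile, would read in this assay at this nitrogen remains open.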